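Expected stability after swapping phenyl for acetamidoethyl

This account rests on a few compounds, and the source may have more. Where it says the series, first, only, none or still open, it means among the compounds named here.

Among the three measured compounds in an ADME assay on microsomes from liver (Rattus norvegicus) for metabolic stability, with a stated time of 10 min (a higher number here means that more of the compound is left, a lower number that less of the compound is left), compound 3 `O=C(NS(=O)(=O)c1ccccc1)c1ccc(Nc2nc(NC3(c4ccc(Cl)cc4)CC3)nc(OCC(F)(F)F)n2)cc1` gives 100%; compound 1 `O=C(NS(=O)(=O)c1ccc(F)cc1)c1ccc(Nc2nc(NC3(c4ccc(Cl)cc4)CC3)nc(OCC(F)(F)F)n2)cc1` gives 99%, which is within the scatter of that, and compound 2 `CCS(=O)(=O)NC(=O)c1ccc(Nc2nc(NC3(c4ccc(Cl)cc4)CC3)nc(OCC(F)(F)F)n2)cc1` gives 85%, which lies beyond the scatter below it. The step to compound 4 `CC(=O)NCCS(=O)(=O)NC(=O)c1ccc(Nc2nc(NC3(c4ccc(Cl)cc4)CC3)nc(OCC(F)(F)F)n2)cc1` replaces (2-acetamidoethyl in place of phenyl on a sulfonyl sulfur). Among the compounds with values here, two measured steps bear on this change: a number 15 percentage points higher from compound 2 to compound 3 (beyond the scatter), and a number 14 percentage points lower from compound 1 to compound 2 (beyond the scatter). In both, the compound carrying an alkyl group on the sulfonyl sulfur shows a modestly lower number than its aryl counterpart, so a downward step of similar size is expected for compound 4, estimated as a number 18 percentage points lower from compound 3 to compound 4 (beyond the scatter). In this assay compound 4 is therefore expected to give 82%, with a likely range from 65% to 98%.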

Compound 4, percent of the compound remaining: 100%
Compound 4: the middle estimate sits 18 percentage points below what was measured; the measured number lies above the stated range.
By their numbers in this assay, from the lowest: compound 2; then compounds 1, 3 and 4 (each within the scatter of the next).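

In this assay, a non-aromatic group on the sulfonyl sulfur does not by itself bring the number down: 2-acetamidoethyl in place of phenyl shows no difference beyond the scatter (no change at the digits printed from compound 3 to compound 4 (within the scatter)), and the same holds in place of 4-fluorophenyl (a number 1 percentage points higher from compound 1 to compound 4 (within the scatter)). Among these compounds, the lower number stays with the ethyl of compound 2, and acetamido on that chain removes the gap (a number 15 percentage points higher from compound 2 to compound 4 (beyond the scatter)). Nothing shown explains this. On these data alone, it remains open whether an amine or a carboxylic acid in place of acetamido would behave alike. The same question stands for a longer chain.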